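The source may report more compounds than this note shows. Statements on the series, on what has been measured and on what is new or still open speak of the compounds shown alone.

Measured so far: compound 1 `CC(C)(C)c1ccc(CNC(=O)Nc2cccc3cnccc23)cc1`, compound 2 `CC1CCN(c2nc(C(F)(F)F)ccc2CNC(=O)Nc2cnc3ccccc3c2)CC1` and compound 3 `CC1CCN(c2nc(C(F)(F)F)ccc2CNC(=O)Nc2cccc3cccnc23)CC1`. In an assay on isolated protein for antagonist activity at transient receptor potential cation channel subfamily V member 1 (Homo sapiens), read by FLIPR (a lower number here means a stronger inhibitor, a higher number a weaker inhibitor), compound 1 gives 13.8 nM, compound 2 gives 9.5 nM, and compound 3 gives 91.6 nM, the highest number of the three. Among the compounds with values here, the one step that bears on the new compound is a 9.6-fold higher number from compound 2 to compound 3 (0.98 log units; beyond the scatter). Compound 4 `CC1CCN(c2nc(C(F)(F)F)ccc2CNC(=O)Nc2cncc3ccccc23)CC1` differs from compound 3 by isoquinolin-4-yl in place of quinolin-8-yl on an amide-type nitrogen. Since a change in the position of the ring nitrogen alone moved the number from compound 2 to compound 3, another such rearrangement is expected to move it again, and compound 1 suggests an attachment at this kind of position can give a low number. Compound 4 is therefore estimated at 30 nM in this assay, between 8 nM and 120 nM, a step of a 3.1-fold lower number from compound 3 to compound 4 (0.48 log units; beyond the scatter).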

Compound 4, inhibition constant: 1.8 nM
Compound 4: the middle estimate sits 17-fold (1.22 log units) above what was measured, and the stated range ends above it.
By their numbers in this assay, from the lowest: compound 4; then compounds 2 and 1 (each within the scatter of the next); then compound 3.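

In this assay, isoquinolin-4-yl in place of quinolin-8-yl on the amide-type nitrogen gives a 51-fold lower number from compound 3 to compound 4 (1.71 log units; beyond the scatter), and in place of quinolin-3-yl it gives a 5.3-fold lower number from compound 2 to compound 4 (0.72 log units; beyond the scatter). Rearranging the same atoms at this position can therefore move the number in either direction from compound 2, as compound 3 and compound 4 show. Nothing measured here accounts for these differences.

Going by these compounds, it remains open whether a naphthyridine group, or a fluorine or an amine on the isoquinolin-4-yl group, would keep this number. The compounds also leave open whether the effect of isoquinolin-4-yl carries over to a different core.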